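Trimming the amide chain of compound 2

The compounds below may be only part of what the source reports. "The series", "measured", "known", "first", "only" and "open" are said of these compounds alone.

Measured so far in a functional assay on K562 cells (Homo sapiens) for antiproliferative activity, read by CCK-8 assay, with a stated time of 72 h; a lower number here means a stronger inhibitor of growth, a higher number a weaker inhibitor of growth:
compound 1 `CCC1C(=O)N(C)c2cnc(Nc3ccc(S(=O)(=O)NCCCO)cc3)nc2N1c1ccn(C)n1` gives 13400 nM
compound 2 `CC[C@@H]1C(=O)N(C)c2cnc(-n3ccc4cc(C(=O)NCC(C)C)ccc43)nc2N1C1CCCC1` gives 638 nM
compound 3 `CCC1C(=O)N(C)c2cnc(Nc3ccc(S(=O)(=O)NC)cc3)nc2N1c1ccn(C)n1` gives 2890 nM

Compound 2 stands lowest of the three numbers in this assay; the gap to compound 3 and the larger gap to compound 1 both lie beyond the scatter. Compound 2 and compound 4 `CCCNC(=O)c1ccc2c(ccn2-c2ncc3c(n2)N(C2CCCC2)[C@H](CC)C(=O)N3C)c1` share the whole core and differ only in the amide chain: hydrogen in place of methyl on a saturated chain carbon bound to two saturated chain carbons.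

Among the compounds with values here, the one measured step is a 4.6-fold lower number from compound 1 to compound 3 (0.67 log units; beyond the scatter). It, too, removes a piece of saturated chain, but on a sulfonamide nitrogen and with a hydroxyl, in a different part of a different series, so it bears on compound 4 only as a sign that shortening a terminal chain on this core can move the number, and then by a modest amount. Within the data shown here, no measured pair shows a methyl leaving a saturated chain carbon bound to two saturated chain carbons. For compound 4 a step of about a 1.2-fold higher number from compound 2 to compound 4 (0.07 log units; within the scatter) is therefore expected, small and possibly within the scatter. The estimate for compound 4 in this assay is 750 nM, with a range from 300 nM to 1900 nM.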

Compound 4, concentration for 50% growth inhibition: 395 nM
Compound 4: the middle estimate sits 1.9-fold (0.28 log units) above what was measured, within the range that was stated.
By their numbers in this assay, from the lowest: compounds 4 and 2 (each within the scatter of the next); then compound 3; then compound 1.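

In this assay the change from isobutyl to propyl on the amide gives a 1.6-fold lower number from compound 2 to compound 4 (0.21 log units; within the scatter) and so shows that this position tolerates the loss of the methyl on a saturated chain carbon bound to two saturated chain carbons, with no difference that can be told from the scatter. Unlike the earlier step on a sulfonamide nitrogen in a different series, this pair changes only the amide chain on the shared core, and it shows that the branch of isobutyl is not required to keep the number of compound 4 level with that of compound 2 in this assay. Nothing available accounts for this tolerance.

Going by these compounds, a single step cannot define a trend with chain size, so it remains open whether an ethyl or methyl on the amide nitrogen, or a longer chain such as pentyl, would leave the number in this assay unmoved. On these data alone, it is equally open whether the position would accept a chain ending in an amine or a carboxylic acid, or a small ring such as cyclopropylmethyl.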